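Hydroxymethyl pattern on the fused core, WiDr cytotoxicity

The source may report more compounds than this note shows. Statements on the series, on what has been measured and on what is new or still open speak of the compounds shown alone.

Measured compounds:
- compound 1 `Cc1c(CO)cc2n1[C@@H](c1ccccc1)SC2`: in a functional assay on WiDr cells (Homo sapiens) for cytotoxicity, read by MTT assay, with a stated time of 48 h (a higher number here means a weaker inhibitor, a lower number a stronger inhibitor), compound 1 gives 17100 nM
- compound 2 `Cc1cc(CO)c2n1[C@@H](c1ccccc1)SC2`: compound 2 gives 95300 nM
- compound 3 `Cc1c(COC(=O)NCc2ccccc2)cc2n1[C@@H](c1ccccc1)SC2`: compound 3 gives 8700 nM

Compound 2 has the highest half-maximal inhibitory concentration of the three, so it is the weakest inhibitor here. Its gap to compound 1 lies beyond the scatter, and so does its larger gap to compound 3; the three values are therefore ordered, with compound 2 last.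

Compound 4 `Cc1c(CO)c(CO)c2n1[C@@H](c1ccccc1)SC2` has not been measured. It differs from compound 2 in one place: hydroxymethyl in place of hydrogen on an aromatic carbon. The resulting compound carries two hydroxymethyl groups on the five-membered aromatic ring and keeps everything else of compound 2. For the measured compounds named here, no measured pair in this set reports exactly this change, so the size of the step is only inferred.

What the numbers show is that compound 1, which carries its hydroxymethyl on the ring carbon that in compound 4 receives the new group, sits well below compound 2. Compound 4 combines both placements, so a move toward compound 1 is expected, but not beyond it. The expected step from compound 2 to compound 4 is a 3.2-fold lower number from compound 2 to compound 4 (0.50 log units; beyond the scatter), that is a moderate gain. Compound 4 is estimated at 30000 nM, with a range from 8000 nM to 110000 nM.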

Compound 4, half-maximal inhibitory concentration: 9100 nM
Estimate against measurement, compound 4: 3.3-fold (0.52 log units) above, within the range that was stated.
By their numbers in this assay, from the lowest: compounds 3, 4 and 1 (each within the scatter of the next); then compound 2.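

In this assay, for the compounds shown here, hydroxymethyl in place of hydrogen on the aromatic carbon next to the ring atom that bears a methyl group gives a 10-fold lower number from compound 2 to compound 4 (1.02 log units; beyond the scatter), a large step and the first one-place change that can be read at this position. The matching change on compound 1, where hydroxymethyl enters instead on the other aromatic carbon, gives a 1.9-fold lower number from compound 1 to compound 4 (0.27 log units; within the scatter), which lies within the scatter, so the same kind of change produces a large step on one parent and no readable step on the other; among these compounds, a hydroxymethyl on the carbon next to the methyl-bearing ring atom accompanies the lower numbers, and adding the other hydroxymethyl to compound 1 does not separate the pair. No measurement at hand explains this difference between the two steps.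

The compounds shown leave open whether this position needs hydroxymethyl itself or would give a similar step with an amine, a carboxylic acid or a longer chain in its place. They also leave open whether compound 2 would show a comparable step if that carbon carried the benzyl carbamate found on compound 3.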